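Working notes: from compound 1 to compound 4

The source may hold more compounds than are shown below. What is called first, only, known or untested is meant among the compounds shown, and "the series" means these compounds.

Of the compounds shown here, three of the shared core have been measured so far. In a functional assay on L1210 cells (Mus musculus), with a stated time of 12 days (a lower number here means a less potent compound, a higher number a more potent compound, by a factor of ten per unit of this negative logarithm), compound 1 `CC1=C(N2CC2)C(=O)C(Cc2ccccc2)=C(N2CC2)C1=O` gives 4.69, the second highest of the three numbers; compound 3 `CCCC1=C(N2CC2)C(=O)C(CCC)=C(N2CC2)C1=O`, at 4.44, sits within the scatter of it, while compound 2 `CCC1=C(N2CC2)C(=O)C(C(COC(N)=O)OC)=C(N2CC2)C1=O`, at 5.22, lies beyond the scatter above it. Compound 4 `CC1=C(N2CC2)C(=O)C(C(C)COC(N)=O)=C(N2CC2)C1=O` has not yet been measured in this assay. It differs from compound 1 in one place: a group of 7 heavy atoms (4 carbon, 1 nitrogen, 2 oxygen; no ring) in place of a group of 7 heavy atoms (7 carbon; one six-membered aromatic ring of carbon only), on a double-bonded ring carbon. For the measured compounds named here, no single-place step between measured compounds is known here, so the size of this step is open; a modest gain is expected rather than a loss, since compound 2, which also carries a carbamate chain, gives 5.22. Compound 4 is therefore estimated at 5, between 4.5 and 5.5, an expected step of a number 0.31 log units higher from compound 1 to compound 4 (beyond the scatter).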

Compound 4, logarithm of the reciprocal of the active concentration, log(1/C): 5.71
For compound 4 the middle estimate is 0.71 log units below the measured one; the measured number lies above the stated range.
By their numbers in this assay, from the lowest: compounds 3 and 1 (each within the scatter of the next); then compound 2; then compound 4.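

At this double-bonded ring carbon, in this assay, the change from benzyl to the group with no ring gives a number 1.02 log units higher from compound 1 to compound 4 (beyond the scatter), so the aromatic ring of benzyl is not needed here for this level of potency. Both groups have the same heavy-atom count, so that count does not account for the step, though the entering group has hydrogen-bond donor and acceptor counts that benzyl lacks. Nothing available explains the size of this step.

The compounds shown do not reveal which part of the entering group carries the gain. Going by these compounds, whether an amine or a carboxylic acid at this place would keep it also remains open.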